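Methyl on the acid chain of compound 2

The source may report more compounds than this note shows. Statements on the series, on what has been measured and on what is new or still open speak of the compounds shown alone.

In a physicochemical assay for solubility, measured as thermodynamic solubility, at pH 7.4 (a lower number here means a less soluble compound, a higher number a more soluble compound), compound 1 (`CCOc1cc2[nH]c(Cc3nn(CC(=O)O)c(=O)c4ccccc34)nc2cc1Cl`) gives 917 ug/mL and compound 2 (`O=C(O)Cn1nc(Cn2cc3cc(OCC4CC4)c(Cl)cc3n2)c2ccccc2c1=O`) gives 334 ug/mL as the lower of the two numbers. The gap between them lies beyond the scatter. Compound 3 (`C[C@H](C(=O)O)n1nc(Cn2cc3cc(OCC4CC4)c(Cl)cc3n2)c2ccccc2c1=O`) differs from compound 2 by methyl in place of hydrogen on a saturated chain carbon bound to an aromatic nitrogen and a carbonyl carbon (carboxymethyl to 1-carboxyethyl), a methyl in place of hydrogen on a saturated chain carbon bound to an aromatic nitrogen and a carbonyl carbon. Within the data shown here, the series holds no measured step of this kind, so the expectation starts from compound 2 at 334 ug/mL alone. The estimated 1.3-fold lower number from compound 2 to compound 3 (0.11 log units; within the scatter) is expected to be a small fall that stays within the scatter. For compound 3 the estimated value is 260 ug/mL (100 ug/mL to 600 ug/mL).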

Compound 3, solubility: 958 ug/mL
Estimate against measurement, compound 3: 3.7-fold (0.57 log units) below; the whole stated range lies below it.
By their numbers in this assay, from the lowest: compound 2; then compounds 1 and 3 (each within the scatter of the next).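

In this assay the position now has its first measured step: the change from carboxymethyl to 1-carboxyethyl gives a 2.9-fold higher number from compound 2 to compound 3 (0.46 log units; beyond the scatter) and is modest in size. So a methyl in place of hydrogen on this saturated chain carbon, bound to an aromatic nitrogen and a carbonyl carbon, moves the read-out upward beyond the scatter with only one heavy atom added, and the carboxylic acid stays in place. No measurement at hand accounts for this step.

Open, on these data alone, is whether the mirror-image form of the 1-carboxyethyl chain, a second methyl on the same carbon, or an ethyl in place of the methyl would read the same way. Among these compounds, also open is whether the same change carries over to the core of compound 1, since only one such step stands.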